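Replacing Cyclopentylamino with Azetidin-1-yl on the Shared Core

The compounds below may be only part of what the source reports. "The series", "measured", "known", "first", "only" and "open" are said of these compounds alone.

Measured so far in a functional assay on HeLa cells (Homo sapiens) for inhibition, read by sulforhodamine B assay; a higher number here means a weaker inhibitor, a lower number a stronger inhibitor:
compound 1 `CCCc1ccc(NC2=CC(=O)c3c(nc4n3[C@H]3OC[C@@H](O)[C@H]3OC4)C2=O)cc1` gives 6030 nM.
compound 2 `O=C1C(NC2CCCC2)=CC(=O)c2c1nc1n2[C@H]2OC[C@@H](O)[C@H]2OC1` gives only a limit, > 16000 nM.
compound 3 `O=C1C(Nc2ccc(C(F)(F)F)cc2)=CC(=O)c2c1nc1n2[C@H]2OC[C@@H](O)[C@H]2OC1` gives 8920 nM.

Compound 2 stands at the floor of this assay: its value is a limit, not a number, at the limit of > 16000 nM in this assay, at which 1 of the 3 values shown sits. Compound 4 `O=C1C(N2CCC2)=CC(=O)c2c1nc1n2[C@H]2OC[C@@H](O)[C@H]2OC1` differs from it by azetidin-1-yl in place of cyclopentylamino on a double-bonded ring carbon. Among the compounds with values here, two measured steps touch the same amine nitrogen: an at least 2.6-fold higher number from compound 1 to compound 2 (0.42 log units; beyond the scatter) and an at least 1.7-fold lower number from compound 2 to compound 3 (0.25 log units; that floor lies within the scatter), both trading cyclopentyl against an aryl ring. Here a smaller ring enters and the amine hydrogen goes, a change no measured step covers. Compound 4 is therefore expected to stay near the floor, with a step that the limit leaves unreadable from compound 2 to compound 4 as the estimated step. The estimate for compound 4 is 20000 nM, between 8000 nM and 50000 nM.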

Compound 4, half-maximal inhibitory concentration: > 16000 nM
Compound 4: no number, only a limit; the forecaster's own chance of this, stated with the estimate: 70%; the middle value lies beyond the limit too.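

Within the data shown here, compound 2 and compound 4 both give a limit rather than a number, so no step between them can be read: the limit of > 16000 nM in this assay, at which 2 of the 4 values shown sit. The compounds shown leave open how azetidin-1-yl compares with cyclopentylamino on the shared core.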